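Chloro Addition on the Methoxy Ring of Compound 1

A few compounds are considered here, and "the series" means these few. Any claim that something is new, unique, unknown or untested is made for them only; others in the source may bear on it.

Going by the values given here, compound 1 `COc1cccc2c1CCC2c1ncc[nH]1` gives 65% in a functional assay on CHO cells for agonist activity at Alpha-1A adrenergic receptor (Homo sapiens), read by FLIPR and calcium flux (on this read-out lower numbers stand for smaller maximal responses and higher numbers for larger maximal responses), the lower of the two numbers measured so far. Compound 2 `CS(=O)(=O)Nc1cccc2c1CCC2c1ncc[nH]1` gives 87%; the step of a number 22 percentage points higher from compound 1 to compound 2 (beyond the scatter) concerns an exchange of the group on the aromatic carbon. Compound 3 `COc1c(Cl)ccc2c1CCC2c1ncc[nH]1` differs from compound 1 by chloro in place of hydrogen on an aromatic carbon. Among the compounds with values here, no measured step bears on this kind of change; the only step known alters a different group and gives no guide to direction. The expected step of a number 3 percentage points higher from compound 1 to compound 3 (within the scatter) is therefore within the scatter. The estimate for compound 3 in this assay is 68%, ranging from 50% to 88%.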

Compound 3, largest response reached (Emax), in percent of the reference or control that the assay uses: 24%
Compound 3: the middle estimate sits 44 percentage points above what was measured; the whole stated range lies above it.
By their numbers in this assay, from the lowest: compound 3; then compound 1; then compound 2.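

In this assay chloro in place of hydrogen, ortho to a methoxy group, gives a number 41 percentage points lower from compound 1 to compound 3 (beyond the scatter) and so counts as a large step. This aromatic carbon, unchanged between the two earlier compounds, clearly bears on the maximal response, and the number moves downward here, whereas the methanesulfonamido exchange on compound 1 moved it upward. No measurement at hand accounts for this drop. Going by these compounds, whether fluoro or methyl on the same carbon also lowers the number remains open. So does whether chloro has a similar effect on compound 2.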